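Methoxy on the bromo compound: solubility outlook

This account rests on a few compounds, and the source may have more. Where it says the series, first, only, none or still open, it means among the compounds named here.

Values in a physicochemical assay for solubility, read by HPLC, at pH 7.4; on this read-out higher numbers stand for higher solubility and lower numbers for lower solubility:
- compound 1 `Cc1[nH]c2ccccc2c(=O)c1C1CCCCC1`: 10000 nM
- compound 2 `Cc1[nH]c2ccccc2c(=O)c1Br`: > 20000 nM (a limit)
- compound 3 `CCCCCCC/C=C/c1c(C)[nH]c2ccccc2c1=O`: < 2000 nM (a limit)

Only compound 1 has a plain number in this assay. Compound 2 gives > 20000 nM, which is a limit and not a number. Compound 3 gives < 2000 nM, which is also a limit.

Compound 4 `COc1ccc2[nH]c(C)c(Br)c(=O)c2c1` carries one change on compound 2: methoxy in place of hydrogen on an aromatic carbon. Methoxy thus stands in place of hydrogen on an aromatic carbon. Among the measured compounds shown here, the one measured step, an at least 2.0-fold higher number from compound 1 to compound 2 (0.30 log units; that floor lies within the scatter), is bromo in place of cyclohexyl, a change elsewhere on the shared core. For the measured compounds named here, no measured step covers methoxy, so no size can be carried over directly. As far as these compounds go, no step beyond the scatter is expected in this assay, and the direction stays open. The expected step is a number no higher from compound 2 to compound 4 (the limit leaves the size open). For compound 4 the estimated value is 20000 nM. The expected range for compound 4 runs from 8000 nM to 40000 nM. A report as a limit is about as likely as a plain number.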

Compound 4, solubility: > 20000 nM
Compound 4: no number, only a limit; the forecaster's own chance of this, stated with the estimate: 55%; the middle value lies on the limit itself.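

Compound 2 gives > 20000 nM in this assay, which is a limit. Compound 4 gives > 20000 nM, also a limit, so no step can be read between compound 2 and compound 4. The compounds shown leave open how large any difference from methoxy in place of hydrogen on an aromatic carbon would be in this assay.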